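From 4-fluorophenyl to 3-chlorophenyl in a cytotoxicity series

The source may hold more compounds than are shown below. What is called first, only, known or untested is meant among the compounds shown, and "the series" means these compounds.

Among the compounds with values here, in a functional assay on B16 cells (Mus musculus) for cytotoxicity, read by CCK-8 assay, with a stated time of 24 h (a lower number here means a stronger inhibitor, a higher number a weaker inhibitor), compound 2 (`COc1ccccc1Oc1c(N)nc(-c2ccc(F)cc2)nc1OCCO`) gives 30100 nM and holds the lower of the two numbers so far; compound 1 (`COc1ccccc1Oc1c(N)nc(-c2cccc(C)c2)nc1OCCO`) gives 70900 nM there. Compound 3 (`COc1ccccc1Oc1c(N)nc(-c2cccc(Cl)c2)nc1OCCO`) carries 3-chlorophenyl in place of 4-fluorophenyl on an aromatic carbon. Within the data shown here, the one measured step bearing on this is modest (a 2.4-fold lower number from compound 1 to compound 2 (0.37 log units; beyond the scatter)) and exchanged 3-methylphenyl for 4-fluorophenyl. With 3-chlorophenyl echoing the 3-methylphenyl of compound 1 (70900 nM), a partial return toward a higher number is expected in this assay and no larger a move than that step. The expected step is small (a 1.7-fold higher number from compound 2 to compound 3 (0.22 log units; within the scatter)). Compound 3 is estimated at 50000 nM (expected range 22000 nM to 110000 nM).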

Compound 3, half-maximal inhibitory concentration: 5010 nM
Beside the measured number, compound 3's estimate is 10-fold (1.00 log units) above it; measured number below the stated range.
By their numbers in this assay, from the lowest: compound 3; then compound 2; then compound 1.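

In this assay, 3-chlorophenyl in place of 4-fluorophenyl gives a 6.0-fold lower number from compound 2 to compound 3 (0.78 log units; beyond the scatter), so this position can respond more strongly than the first pair showed. Chloro in place of methyl on the same phenyl ring gives a 14-fold lower number from compound 1 to compound 3 (1.15 log units; beyond the scatter), the largest step so far, so two groups with the same placement on that ring can differ widely. No available evidence accounts for this gain. The compounds shown leave open whether 4-chlorophenyl would match compound 3, which would help separate the choice of halogen from its placement. They also leave open how an amine or a carboxylic acid on the phenyl ring would fare.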